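This account rests on a few compounds, and the source may have more. Where it says the series, first, only, none or still open, it means among the compounds named here.

The study set two acyclic-chain analogues against a functional assay (Oryctolagus cuniculus) for inhibition; on this read-out higher numbers stand for weaker inhibition and lower numbers for stronger inhibition. Compound 1 `OCCOCn1cnc2c(O)ncnc21` carries a hydroxy on its core; in this assay compound 1 gives only a limit, > 100 ug/mL. Compound 2 `Nc1nc(Cl)c2ncn(COCCO)c2n1` carries an amino group and a chloro on the core and the same 2-hydroxyethyl chain on the ring nitrogen. In this assay compound 2 likewise gives only a limit, > 100 ug/mL. Compound 2 therefore stands at the limit of > 100 ug/mL in this assay, at which 2 of the 2 values shown sit, so nothing among the numbers shown separates it from compound 1.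

Compound 3 `CC(=O)OCCOCn1cnc2c(Cl)nc(N)nc21` is the next compound to be tested in this assay. It differs from compound 2 by a single change: acetyl in place of hydrogen on an oxygen on a saturated carbon. Among the measured compounds shown here, no step between two measured compounds is available to calibrate what an acetyl in place of hydrogen on this oxygen does, and both measured compounds sit at the limit.

The expectation for compound 3 is that the step that the limit leaves unreadable from compound 2 to compound 3 stays within the scatter, with compound 3 most likely again returning only a limit. The estimate for compound 3 in this assay is 150 ug/mL, between 40 ug/mL and 600 ug/mL.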

Compound 3, concentration for 50% inhibition: 71 ug/mL
Compound 3: the middle estimate sits 2.1-fold (0.32 log units) above what was measured, within the range that was stated.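

Of the compounds shown, compound 3 is the only one that returns a number rather than a limit in this assay, at 71 ug/mL, so this read-out can register inhibition for a compound with this chain and the core of compound 2. The change from 2-hydroxyethyl to 2-acetoxyethyl, with acetyl in place of hydrogen on an oxygen on a saturated carbon, gives an at least 1.4-fold lower number from compound 2 to compound 3 (0.14 log units; that floor lies within the scatter), which shows that this oxygen can carry an acetyl and still give a number in this assay, though the printed floor alone does not establish a real gain. The true size of the step stays unknown because compound 2 gives only a limit: the limit of > 100 ug/mL in this assay, at which 2 of the 3 values shown sit.

What the compounds shown leave open is how far the step from compound 2 to compound 3 really reaches beyond its floor, and whether the same acetyl on the chain of compound 1, with its hydroxy on the core, would also bring a number within reach. Going by these compounds, it also remains open whether a longer acyl chain such as butyryl, or a benzoyl or a methyl on the same oxygen, would behave as the acetyl does.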